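Swapping the aryl group: compound 3 to compound 4

The source may report more compounds than this note shows. Statements on the series, on what has been measured and on what is new or still open speak of the compounds shown alone.

In a functional assay on L1210 cells (Mus musculus) for antiproliferative activity (a higher number here means a weaker inhibitor, a lower number a stronger inhibitor), compound 3 (`COc1cc(C(=O)c2sc(-c3ccsc3)cc2N)cc(OC)c1OC`) gives 12 nM. This lies within the scatter of the two other measured compounds: compound 1 (`COc1cc(C(=O)c2sc(-c3cccc([N+](=O)[O-])c3)cc2N)cc(OC)c1OC`) gives 11 nM and compound 2 (`COc1cc(C(=O)c2sc(-c3ccccc3)cc2N)cc(OC)c1OC`) gives 11 nM.

The next compound, compound 4 (`CCOc1ccc(-c2cc(N)c(C(=O)c3cc(OC)c(OC)c(OC)c3)s2)cc1`), carries 4-ethoxyphenyl in place of thiophen-3-yl on an aromatic carbon, next to the ring sulfur: 4-ethoxyphenyl in place of thiophen-3-yl on an aromatic carbon.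

Three measured steps alter the group at this same place: no change at the digits printed from compound 1 to compound 2 (within the scatter), a 1.1-fold higher number from compound 1 to compound 3 (0.04 log units; within the scatter) and a 1.1-fold higher number from compound 2 to compound 3 (0.04 log units; within the scatter). All three lie within the scatter, so 3-nitrophenyl, phenyl and thiophen-3-yl cannot be told apart on these numbers. Among the measured compounds shown here, no measured compound carries 4-ethoxyphenyl, so this flat picture is an uncertain guide and the range stays wide on both sides.

No step beyond the scatter is expected in this assay. The expected step is a 1.2-fold lower number from compound 3 to compound 4 (0.08 log units; within the scatter). For compound 4 the estimated value is 10 nM, with an expected range of 2.5 nM to 40 nM.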

Compound 4, half-maximal inhibitory concentration: 590 nM
The estimate for compound 4 lay 59-fold (1.77 log units) below the measured number; measured number outside the range, above it.
By their numbers in this assay, from the lowest: compounds 1, 2 and 3 (each within the scatter of the next); then compound 4.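

In this assay, the group on the aromatic carbon next to the ring sulfur is not freely exchangeable: adding ethoxy to the phenyl group gives a 54-fold higher number from compound 2 to compound 4 (1.73 log units; beyond the scatter). The same loss appears against the other two groups, with a 49-fold higher number from compound 3 to compound 4 (1.69 log units; beyond the scatter) and a 54-fold higher number from compound 1 to compound 4 (1.73 log units; beyond the scatter), so the tolerance shared by 3-nitrophenyl, phenyl and thiophen-3-yl does not extend to 4-ethoxyphenyl. No evidence is available on what lies behind this step.

The compounds shown leave open whether the loss is specific to ethoxy or also occurs with a hydroxyl, a methoxy or a longer alkoxy chain on the phenyl ring. Among the compounds shown here, with only one such substituted group in hand, the point at which activity falls away cannot be located.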